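The source may hold more compounds than are shown below. What is called first, only, known or untested is meant among the compounds shown, and "the series" means these compounds.

Three compounds share one core and differ only in what sits on one aromatic nitrogen and in one ring substituent. Compound 1 `CC(C)c1onc(-c2c(Cl)cccc2Cl)c1COc1ccc(-c2nc3ccc(C(=O)O)cc3n2CC(C)(C)C)cc1` carries a neopentyl group there; in an assay on Huh-7 cells for agonist activity at Bile acid receptor (Homo sapiens), read by a luciferase reporter (a higher number here means that more compound is needed for the effect, a lower number that less compound is needed), compound 1 gives 13 nM. Compound 2 `CC(C)c1onc(-c2c(Cl)cccc2Cl)c1COc1ccc(-c2nc3ccc(C(=O)O)cc3n2C2CC2)cc1` carries a cyclopropyl group instead; in this assay compound 2 gives 16.5 nM. Compound 3 `CC(C)c1onc(-c2c(Cl)cccc2Cl)c1COc1ccc(-c2nc3ccc(C(=O)O)cc3n2C)c(Cl)c1` carries a methyl group and an added chlorine; in this assay compound 3 gives 3.66 nM. Among these three, compound 2 stands at the top of the range of numbers: its nearest neighbour is compound 1, with a 1.3-fold higher number from compound 1 to compound 2 (0.10 log units; within the scatter), and its furthest is compound 3, whose number is lower by a gap beyond the scatter.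

Compound 4 `CC(C)c1onc(-c2c(Cl)cccc2Cl)c1COc1ccc(-c2nc3ccc(C(=O)O)cc3n2C2CCCCC2)cc1` is next, and it is cyclohexyl in place of cyclopropyl on an aromatic nitrogen. Among the compounds with values here, the one measured step at this place, a 1.3-fold higher number from compound 1 to compound 2 (0.10 log units; within the scatter), stayed within the scatter. Within the data shown here, only that single step bears on the change, so for compound 4 the expectation is a 1.0-fold lower number from compound 2 to compound 4 (0.01 log units; within the scatter), no step beyond the scatter. Compound 4 is therefore estimated at 16 nM, within a range from 6 nM to 45 nM.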

Compound 4, half-maximal effective concentration: 4.21 nM
Beside the measured number, compound 4's estimate is 3.8-fold (0.58 log units) above it; the measured number lies below the stated range.
By their numbers in this assay, from the lowest: compounds 3 and 4 (each within the scatter of the next); then compounds 1 and 2 (each within the scatter of the next).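

Until now, the group on this aromatic nitrogen seemed to matter little in this assay, but the swap to cyclohexyl shows that this position can move the number beyond the scatter, with a 3.9-fold lower number from compound 2 to compound 4 (0.59 log units; beyond the scatter) and a 3.1-fold lower number from compound 1 to compound 4 (0.49 log units; beyond the scatter) as well. Both steps are modest, yet they point the same way: cyclohexyl needs less compound for the effect than either cyclopropyl or neopentyl, although all three groups are made of carbon only and have no hydrogen-bond donors or acceptors. Nothing available explains why this six-membered ring gives the lower number.

From the compounds shown here alone, it remains open whether a cyclopentyl ring would behave like cyclohexyl, or whether a six-membered ring carrying an oxygen atom or an amine would keep the gain. Going by these compounds, it is also open whether the added chlorine of compound 3 would combine with cyclohexyl on the shared core.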